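Removing an ortho methyl from the amide aryl ring

This account rests on a few compounds, and the source may have more. Where it says the series, first, only, none or still open, it means among the compounds named here.

Measured compounds:
compound 1 `O=C(Nc1ccccc1Cl)c1ccc(/N=N\c2c[nH]c3ccccc23)cc1` — 120000 nM
compound 2 `Cc1ccc(C)c(NC(=O)c2ccc(/N=N\c3c[nH]c4ccccc34)cc2)c1` — 544000 nM

In a functional assay on HCT-116 cells (Homo sapiens) for inhibition, read by MTT assay, with a stated time of 72 h (on this read-out higher numbers stand for weaker inhibition and lower numbers for stronger inhibition), compound 1 gives 120000 nM, and compound 2 gives 544000 nM. Compound 2 therefore stands at the higher of the two numbers, set apart by a 4.5-fold higher number from compound 1 to compound 2 (0.66 log units; beyond the scatter). That step swaps the whole substituted ring, so it bears only loosely on the next change. Compound 3 `Cc1cccc(NC(=O)c2ccc(/N=N\c3c[nH]c4ccccc34)cc2)c1` differs from compound 2 by hydrogen in place of methyl on an aromatic carbon. Among the compounds with values here, no measured pair isolates the loss of a single methyl from this ring; the one step available mixes a change of the group at that position with the gain of a second methyl. The size of the expected step is thus uncertain, and compound 3 is estimated to land at about 350000 nM, with a range of 120000 nM to 1000000 nM, meaning an expected step of a 1.6-fold lower number from compound 2 to compound 3 (0.19 log units; within the scatter) that may well lie within the scatter.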

Compound 3, half-maximal inhibitory concentration: 98900 nM
For compound 3 the middle estimate is 3.5-fold (0.55 log units) above the measured one, and the stated range ends above it.
By their numbers in this assay, from the lowest: compounds 3 and 1 (each within the scatter of the next); then compound 2.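

In this assay, the methyl on the aromatic carbon ortho to a large group now has a measured effect of its own: going from 2,5-dimethylphenyl to 3-methylphenyl gives a 5.5-fold lower number from compound 2 to compound 3 (0.74 log units; beyond the scatter) on loss of that one carbon. The comparison with the chlorine-bearing ring gives a 1.2-fold lower number from compound 1 to compound 3 (0.08 log units; within the scatter) for 3-methylphenyl in place of 2-chlorophenyl, so these two rings cannot be told apart here, and among these three compounds only compound 2 stands apart. Nothing available explains this step.

The compounds shown leave open whether the effect is specific to methyl at this carbon or would also appear with a methoxy group, a fluorine or an ethyl group there. They also leave open what the remaining methyl contributes, which a plain phenyl ring on the amide nitrogen would address.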